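Methoxycarbonyl to ethoxycarbonyl: compound 3 to compound 4

The compounds below may be only part of what the source reports. "The series", "measured", "known", "first", "only" and "open" are said of these compounds alone.

Values in a functional assay on HeLa cells (Homo sapiens) for antiproliferative activity, read by MTT assay, with a stated time of 48 h; a lower number here means a stronger inhibitor of growth, a higher number a weaker inhibitor of growth
compound 1 `CCOC(=O)N1N=C(c2ccccc2)CC1c1cc(OC)c(OC)c(OC)c1` - 8230 nM
compound 2 `CCOC(=O)N1N=C(c2cccc(OC)c2)CC1c1cc(OC)c(OC)c(OC)c1` - 4110 nM
compound 3 `COC(=O)N1N=C(c2ccc(OC)cc2)CC1c1cc(OC)c(OC)c(OC)c1` - 2590 nM

Compound 3 lies within the scatter of compound 2 and clearly lower than compound 1 in this assay on these numbers. Compound 4 `CCOC(=O)N1N=C(c2ccc(OC)cc2)CC1c1cc(OC)c(OC)c(OC)c1` differs from compound 3 by methyl in place of hydrogen on a saturated chain carbon bound to an oxygen next to a carbonyl group, methoxy to ethoxy. For the measured compounds named here, the single measured step, a 2.0-fold lower number from compound 1 to compound 2 (0.30 log units; within the scatter), concerns methoxy in place of hydrogen on an aromatic carbon, so no measured pair isolates this change. No step beyond the scatter is expected in this assay here. The expected step is a 1.2-fold higher number from compound 3 to compound 4 (0.06 log units; within the scatter). Compound 4 is estimated at 3000 nM, within a range of 1400 nM to 6000 nM.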

Compound 4, concentration for 50% growth inhibition: 8710 nM
Estimate against measurement, compound 4: 2.9-fold (0.46 log units) below; measured number above the stated range.
By their numbers in this assay, from the lowest: compounds 3, 2, 1 and 4 (each within the scatter of the next, the first and the last beyond it).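

In this assay, the position is sensitive to a small change: methyl in place of hydrogen, methoxy to ethoxy, gives a 3.4-fold higher number from compound 3 to compound 4 (0.53 log units; beyond the scatter). With ethoxycarbonyl held, 4-methoxyphenyl in place of 3-methoxyphenyl gives a 2.1-fold higher number from compound 2 to compound 4 (0.33 log units; beyond the scatter), whereas methoxy in place of hydrogen on the aromatic carbon gives a 1.1-fold higher number from compound 1 to compound 4 (0.02 log units; within the scatter). The low number of compound 3 therefore does not carry over to its ethoxycarbonyl counterpart.

As far as these compounds go, whether a longer chain, such as propyl, on this oxygen would shift the number further remains open. No measurement available accounts for these steps.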